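The source may report more compounds than this note shows. Statements on the series, on what has been measured and on what is new or still open speak of the compounds shown alone.

Compounds measured in an ADME assay on RAW264.7 cells (Mus musculus) for cytotoxicity, read by MTT assay, with a stated time of 48 h; a lower number here means a stronger inhibitor, a higher number a weaker inhibitor:
Compound 1 `CCS(=O)(=O)Nc1ccc(NC(=O)c2cc(C(F)(F)F)cc(C(F)(F)F)c2)cc1OC` gives > 250000 nM, which is a limit of the assay rather than a number.
Compound 2 `COc1cc(NC(=O)c2cccc(C(F)(F)F)c2)ccc1NS(=O)(=O)C(F)(F)F` gives 75200 nM.
Compound 3 `COc1cc(NC(=O)c2cc(C(F)(F)F)cc(C(F)(F)F)c2)ccc1NS(=O)(=O)C(F)(F)F` gives > 250000 nM, again a limit of the assay and not a number.

Compound 3 therefore stands at the limit of > 250000 nM in this assay, at which 2 of the 3 values shown sit, and only a bound is known for it. The step from compound 1 to compound 3 , trifluoromethyl in place of ethyl on a sulfonyl sulfur, is a step that the two limits leave unreadable from compound 1 to compound 3. The step from compound 2 to compound 3 , trifluoromethyl in place of hydrogen on an aromatic carbon, is an at least 3.3-fold higher number from compound 2 to compound 3 (0.52 log units; beyond the scatter).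

Compound 4 `O=C(Nc1ccc(NS(=O)(=O)C(F)(F)F)c(Cl)c1)c1cc(C(F)(F)F)cc(C(F)(F)F)c1` differs from compound 3 by chloro in place of methoxy on an aromatic carbon, a change ortho to a ((trifluoromethyl)sulfonyl)amino group. Neither measured step touches this position or this kind of exchange, so neither bears directly on it, and the two limits give no direction to read from. With compound 3 already at the bound and no relevant step shown, the expectation is that compound 4 shows no step beyond the scatter, a step that the limit leaves unreadable from compound 3 to compound 4. Compound 4 is thus estimated at 300000 nM, within a range from 100000 nM to 1000000 nM, and it is expected that this assay will most likely again report only a limit for it.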

Compound 4, half-maximal inhibitory concentration: 136000 nM
Estimate against measurement, compound 4: 2.2-fold (0.34 log units) above; low and high end bracket the measured number.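

Compound 3 stands at a limit of the assay and not at a number: the limit of > 250000 nM in this assay, at which 2 of the 4 values shown sit.

At this aromatic carbon, ortho to a ((trifluoromethyl)sulfonyl)amino group, chloro in place of methoxy gives the first exchange at this position among the compounds shown, and in this assay compound 4 reads 136000 nM, a measured number and not a limit. As far as these compounds go, the change is an at least 1.8-fold lower number from compound 3 to compound 4 (0.26 log units; that floor lies within the scatter), so its direction can be read, while its true size remains unknown and could be larger than that floor.

The compounds shown do not tell whether this change follows from chloro itself or from the loss of methoxy, as no other group at this position, such as fluoro, methyl or an amine, stands among them. From the compounds shown here alone, it also remains open whether the same exchange would give a comparable step on the core of compound 2, which carries one trifluoromethyl fewer, or on that of compound 1, which carries ethyl on the sulfonyl sulfur.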